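The source may report more compounds than this note shows. Statements on the series, on what has been measured and on what is new or still open speak of the compounds shown alone.

Measured so far:
compound 1, `CCc1ccc(NC(=O)CN2CCN(c3ccc(F)cc3)CC2)cc1`: 50%
compound 2, `N#Cc1ccc(NC(=O)CN2CCN(c3ccc(F)cc3)CC2)cc1`: 50%

In an assay for displacement of a labelled ligand from DNA repair protein REV1 (Homo sapiens), read by fluorescence polarization, with a stated time of 1 h, tested at 1 uM (on this read-out higher numbers stand for more inhibition at the one concentration tested (going by the name of the read-out) and lower numbers for less inhibition), compound 1 gives 50% and stands level with compound 2, which gives 50%; the step of no change at the digits printed from compound 1 to compound 2 (within the scatter) stays within the scatter. Compound 3, `CCc1ccc(NC(=O)CN2CCN(c3ccc(OC)cc3)CC2)cc1`, has not yet been measured. It differs from compound 1 by methoxy in place of fluoro on an aromatic carbon. Going by the values given here, only one measured step exists, and it exchanges cyano for ethyl, not fluoro for methoxy, so it does not bear directly on the change from compound 1 to compound 3; it shows merely that the one exchange tried so far left this assay flat. Among the compounds with values here, with no step on the fluoro position to draw on, the expected step from compound 1 to compound 3 in this assay is none beyond the scatter, in either direction, no change at the digits printed from compound 1 to compound 3 (within the scatter). Compound 3 is therefore estimated at 50%, with a range from 30% to 70%.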

Compound 3, a percentage reported as inhibition, at one concentration (the size of the read-out at that concentration, not a potency): 50%
Compound 3: middle estimate and measured number agree at the digits printed; measured number inside the range.
By their numbers in this assay, from the lowest: compounds 1, 2 and 3 (each within the scatter of the next).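

In this assay, going by these compounds alone, methoxy in place of fluoro gives no change at the digits printed from compound 1 to compound 3 (within the scatter) and so provides the first reading at this aromatic carbon, since the earlier pair had changed a different place in the molecule. The 4-fluorophenyl to 4-methoxyphenyl exchange swaps a lone fluorine for a group with a carbon and an oxygen, and the read-out stays flat across it. With compound 1 as the reference, exchanges at two separate places have now left the read-out within the scatter, and no independent evidence accounts for this.

As far as these compounds go, whether a carboxylic acid, an amine or a longer chain such as butoxy on this aromatic carbon would move the read-out beyond the scatter remains open. Also open, from the compounds shown here alone, is whether compound 1 and compound 3 would still stand level at concentrations other than the single one tested.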